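The compounds below may be only part of what the source reports. "The series", "measured", "known", "first", "only" and "open" are said of these compounds alone.

Notes on the series. The shared core carries a chlorine and an amide link; compound 1 `CC(C)(C)C[C@H](N)C(=O)Nc1cc2cc[nH]c(=O)c2cc1Cl` bears a 1-amino-3,3-dimethylbutyl chain on the amide carbonyl. In an assay on isolated protein for inhibition of Rho-associated protein kinase 2 (Homo sapiens) (a lower number here means a stronger inhibitor, a higher number a weaker inhibitor), compound 1 gives 845 nM. Compound 2 `CN(C)[C@H]1CC[C@@H](C(=O)Nc2cc3cc[nH]c(=O)c3cc2Cl)CC1` replaces that chain with a dimethylamino-substituted cyclohexyl; in this assay compound 2 gives 1000 nM. Compound 1 has the lowest of the two numbers, but its gap to compound 2 lies within the scatter, so no order between the two can be read.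

Compound 3 `CC(C)C[C@H](N)C(=O)Nc1cc2cc[nH]c(=O)c2cc1Cl` is the not yet measured analogue of compound 1 with the change (hydrogen in place of methyl on a saturated chain carbon bound to three saturated chain carbons), that is, neopentyl to isobutyl. Going by the values given here, no measured pair here shows the effect of removing one methyl from a saturated chain, so nothing anchors the step. A small step, no larger than the scatter, is expected for compound 3, estimated as a 1.3-fold higher number from compound 1 to compound 3 (0.11 log units; within the scatter), leaning slightly toward a higher number. The value expected for compound 3 in this assay is 1100 nM, with a range from 400 nM to 3000 nM.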

Compound 3, half-maximal inhibitory concentration: 340 nM
For compound 3 the middle estimate is 3.2-fold (0.51 log units) above the measured one; the measured number lies below the stated range.
By their numbers in this assay, from the lowest: compound 3; then compounds 1 and 2 (each within the scatter of the next).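

Hydrogen in place of methyl on a saturated chain carbon bound to three saturated chain carbons gives a 2.5-fold lower number from compound 1 to compound 3 (0.40 log units; beyond the scatter) in this assay. Going by these compounds alone, this is the first step that can be read, and it shows that the end of this chain is sensitive to the loss of a single methyl: the tert-butyl end of compound 1 is not required, and the isopropyl end of compound 3 gives the lower number. Nothing available bears on what lies behind this step.

Going by these compounds, whether the number keeps falling as the chain end shrinks further, to an ethyl or a methyl, remains open. Also open, on these data alone, is how a cyclopropyl or a phenyl at the chain end, or a dimethylamino group in place of the amine on this chain, would read.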